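A few compounds are considered here, and "the series" means these few. Any claim that something is new, unique, unknown or untested is made for them only; others in the source may bear on it.

Measured in a functional assay on HeLa cells (Homo sapiens) for inhibition, read by CCK-8 assay, with a stated time of 48 h (on this read-out lower numbers stand for stronger inhibition and higher numbers for weaker inhibition), where every value so far is a limit of the assay and not a number:

Compound 1 `Nc1ccc(Oc2ccccc2-c2ccc(S(=O)(=O)NCCNC(=O)Nc3ccc(Cl)cc3)s2)cc1`: > 20000 nM
Compound 2 `O=C(Nc1cccc([N+](=O)[O-])c1)N1CCN(S(=O)(=O)c2sccc2-c2ccccc2Oc2ccc(O)c(O)c2)CC1`: > 20000 nM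
Compound 3 `COc1ccc(Oc2ccc([N+](=O)[O-])cc2-c2ccsc2S(=O)(=O)N2CCN(C(=O)Nc3ccc([N+](=O)[O-])cc3)CC2)cc1OC`: > 50000 nM

Compound 2 gives only a limit, > 20000 nM, and so stands on (the limit of > 20000 nM in this assay, at which 2 of the 3 values shown sit). Compound 4 `O=C(Nc1ccc([N+](=O)[O-])cc1)N1CCN(S(=O)(=O)c2sccc2-c2ccccc2Oc2ccc(O)c(O)c2)CC1` has not yet been measured. It carries 4-nitrophenyl in place of 3-nitrophenyl on an amide-type nitrogen. Within the data shown here, no measured pair in this assay gives the size of such a change, so no step beyond the scatter is expected, in either direction. The estimated step is a step that the limit leaves unreadable from compound 2 to compound 4. For compound 4 the estimate is 25000 nM, with an expected range from 8000 nM to 60000 nM.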

Compound 4, half-maximal inhibitory concentration: > 20000 nM
Compound 4: a limit, no number (the forecaster's own chance of this, stated with the estimate: 65%); the middle value lies beyond the limit too.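

Compound 2 and compound 4 each give only a limit of the assay, and the step between them cannot be read. The compounds shown leave open what 4-nitrophenyl in place of 3-nitrophenyl on an amide-type nitrogen does to inhibition.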